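The source may report more compounds than this note shows. Statements on the series, on what has been measured and on what is new or still open speak of the compounds shown alone.

Measured in a functional assay on aorta (Rattus norvegicus, strain Wister); a lower number here means a stronger inhibitor, a higher number a weaker inhibitor:
- compound 1, `COc1nc(-c2nc3ccccc3[nH]2)cc(-c2ccc(Cl)cc2)c1C#N`; compound 1 gives 286000 nM
- compound 2, `COc1nc(-c2nc3ccccc3n2C)cc(-c2ccc(Cl)cc2Cl)c1C#N`; compound 2 gives 214000 nM
- compound 3, `CCOc1nc(-c2nc3ccccc3n2C)cc(-c2ccc(Cl)cc2Cl)c1C#N`; compound 3 gives 305000 nM

Compound 3 holds the highest of the three numbers, yet compound 1 and compound 2 both lie within the usual scatter of it, so the three values are treated as one level. Within the data shown here, the only single-point step measured is a 1.4-fold higher number from compound 2 to compound 3 (0.15 log units; within the scatter), which concerns the ethoxy group and not the aryl group.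

Compound 4, `CCOc1nc(-c2nc3ccccc3n2C)cc(-c2ccc(OC)cc2)c1C#N`, differs from compound 3 by 4-methoxyphenyl in place of 2,4-dichlorophenyl on an aromatic carbon. Among the measured compounds shown here, no measured step exchanges this aryl group. Compound 1 and compound 2 differ in two places at once, and their values in this assay sit within the scatter of each other, so they give no direction for the present change. The step from compound 3 to compound 4 is therefore expected to stay within the scatter, a 1.0-fold lower number from compound 3 to compound 4 (0.01 log units; within the scatter), with a wide range for an untested exchange. Compound 4 is estimated at 300000 nM, between 100000 nM and 900000 nM.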

Compound 4, half-maximal inhibitory concentration: 436000 nM
For compound 4 the middle estimate is 1.5-fold (0.16 log units) below the measured one; low and high end bracket the measured number.
By their numbers in this assay, from the lowest: compounds 2, 1, 3 and 4 (each within the scatter of the next, the first and the last beyond it).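

In this assay, the position opposite the ring nitrogen now has its first single-place aryl exchange: 4-methoxyphenyl in place of 2,4-dichlorophenyl gives a 1.4-fold higher number from compound 3 to compound 4 (0.16 log units; within the scatter). With the ethoxy group and the rest of the core held constant, this position therefore tolerates loss of both chlorines and gain of a methoxy group, with one more hydrogen-bond acceptor and the same heavy-atom count, without a step beyond the scatter. Nothing available explains this result or connects it to a measured property.

As far as these compounds go, it remains open whether an aryl group bearing an amine or a carboxylic acid at this position would move the number in this assay beyond the scatter. The response to a longer chain in place of the ethoxy group, with either aryl group present, is also unresolved.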